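A Methyl Shift on the Aryl Sulfonate

A few compounds are considered here, and "the series" means these few. Any claim that something is new, unique, unknown or untested is made for them only; others in the source may bear on it.

Measured values from a functional assay on M21 cells (Homo sapiens) for antiproliferative activity, read by sulforhodamine B assay, with a stated time of 48 h (on this read-out higher numbers stand for weaker inhibition and lower numbers for stronger inhibition), are as follows
- Compound 1 `Cc1ccccc1OS(=O)(=O)c1ccc(N2CCN(C)C2=O)cc1` gives 2900 nM here
- Compound 2 `CN1CCN(c2ccc(S(=O)(=O)Oc3cc(Cl)c(Cl)cc3Cl)cc2)C1=O` gives 420 nM here

Of these two compounds, compound 1 carries the highest number, and so the weaker inhibition. Compound 2 stands lower, and the gap between the two lies beyond the usual scatter of repeated measurements.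

Compound 3 `Cc1cccc(OS(=O)(=O)c2ccc(N3CCN(C)C3=O)cc2)c1` has not yet been measured. It has the same atoms as compound 1, joined differently: 3-methylphenyl in place of 2-methylphenyl on an oxygen while the rest of the molecule stays the same. Within the data shown here, no measured pair shows what this change does, so the expectation is anchored on compound 1 at 2900 nM and remains cautious. In this assay a small step towards a lower number is expected, one that does not go beyond the scatter. The estimated size is a 1.5-fold lower number from compound 1 to compound 3 (0.16 log units; within the scatter) in this account. For compound 3 the expected value is 2000 nM with an estimated range from 700 nM to 6000 nM in this assay.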

Compound 3, half-maximal inhibitory concentration: 2300 nM
Beside the measured number, compound 3's estimate is 1.2-fold (0.06 log units) below it, within the range that was stated.
By their numbers in this assay, from the lowest: compound 2; then compounds 3 and 1 (each within the scatter of the next).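

In this assay, placing 3-methylphenyl instead of 2-methylphenyl on the oxygen bound to the sulfonyl sulfur gives a 1.3-fold lower number from compound 1 to compound 3 (0.10 log units; within the scatter), so this read-out does not separate the two isomers. Among these compounds, this is the first pair that differs in one place, and it isolates the attachment point of the methyl, since the two groups have the same atoms and the rest of the molecule stays the same. Between these two attachment points, the methyl's location makes no difference that can be told from the scatter, and no measurement is available to explain that outcome.

The compounds shown leave open whether the methyl matters at all on this ring, as no plain phenyl sulfonate offers a direct comparison, and whether a methoxy group, an amine or a carboxylic acid in its place would give a step beyond the scatter. They also do not show whether the chlorines of compound 2 act singly or only together, which would take aryl groups carrying one chlorine or two.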